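The compounds below may be only part of what the source reports. "The series", "measured", "known", "first", "only" and "open" are said of these compounds alone.

Measured so far in a functional assay on SW480 cells (Homo sapiens) for antiproliferative activity, read by MTT assay, with a stated time of 48 h; a higher number here means a weaker inhibitor, a lower number a stronger inhibitor:
- compound 1 `C=C(CO)C(CCCCCC)n1cnc2c(Cl)ncnc21` gives 32000 nM
- compound 2 `C=C(CO)C(CCCCCCCC)n1cnc2c(Cl)ncnc21` gives 16200 nM
- compound 3 `CCCCCCCCCC(CCCl)n1cnc2c(Cl)ncnc21` gives 7180 nM

Compound 3 has the lowest number of the three, and its gaps to compound 1 and compound 2 both lie beyond the scatter, so it is the strongest inhibitor in this small set. The next compound, compound 4 (`C=C(CO)C(CCCCCCCCC)n1cnc2c(Cl)ncnc21`), puts 1-(hydroxymethyl)ethenyl in place of 2-chloroethyl on a saturated chain carbon bound to an aromatic nitrogen and a saturated chain carbon.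

For the measured compounds named here, no measured step makes this exact swap, so the evidence is indirect. Compound 1 and compound 2 already carry the entering group, and both have higher numbers than compound 3. Going by the values given here, the one step between them, a 2.0-fold lower number from compound 1 to compound 2 (0.30 log units; within the scatter), says little about how a longer chain would behave, such as the one in compound 4. Compound 2 is the closest guide, at 16200 nM, and the chain of compound 4 may bring the number slightly lower than that.

In this assay the expected step is a 1.5-fold higher number from compound 3 to compound 4 (0.19 log units; within the scatter) (a modest move towards weaker inhibition, and an uncertain one). For compound 4 the estimated value is 11000 nM (expected range 5000 nM to 22000 nM).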

Compound 4, half-maximal inhibitory concentration: 27600 nM
Compound 4: the middle estimate sits 2.5-fold (0.40 log units) below what was measured, and the stated range ends below it.
By their numbers in this assay, from the lowest: compound 3; then compounds 2, 4 and 1 (each within the scatter of the next).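

In this assay, for the compounds shown here, putting 1-(hydroxymethyl)ethenyl in place of 2-chloroethyl on this saturated chain carbon gives a 3.8-fold higher number from compound 3 to compound 4 (0.58 log units; beyond the scatter), a step beyond the scatter and the first direct reading of this swap, so 2-chloroethyl is the stronger of the two groups on this chain. Chain length tells much less among the compounds that carry 1-(hydroxymethyl)ethenyl: a 1.7-fold higher number from compound 2 to compound 4 (0.23 log units; within the scatter) and a 1.2-fold lower number from compound 1 to compound 4 (0.06 log units; within the scatter) both lie within the scatter, so compound 4 cannot be ranked against either compound, and the longer chain brings no clear gain here. Nothing available explains why the two groups differ.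

Going by these compounds alone, compound 3 is the only compound here with 2-chloroethyl, so it remains open whether this group would keep its advantage on a shorter or longer chain. The swap also changes the chlorine, the double bond and the hydroxyl group all at once, which leaves open how a simple 2-hydroxyethyl group or an amine at this position would read in this assay.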